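Ethylamino analogues across two cores

The compounds below may be only part of what the source reports. "The series", "measured", "known", "first", "only" and "open" are said of these compounds alone.

Compound 1 `CNCC(=O)Nc1cc(OC)ccc1C(=O)c1ccc(OC)c2c1OC(C)(C)C=C2` and compound 2 `CNCC(=O)Nc1cc(OC)ccc1C(=O)c1ccc2c(c1)C=CC(C)(C)O2` carry the same (methylamino)methyl amide side chain; how their two cores differ is not broken down here. In a functional assay on HCT-8 cells (Homo sapiens) for antiproliferative activity, read by MTT assay, with a stated time of 48 h (a lower number here means a stronger inhibitor, a higher number a weaker inhibitor), compound 1 gives 740 nM, and compound 2 gives 1010 nM, a gap within the scatter. Compound 3 `CCNCC(=O)Nc1cc(OC)ccc1C(=O)c1ccc(OC)c2c1OC(C)(C)C=C2` shows methyl in place of hydrogen on a saturated chain carbon bound to an amine nitrogen on the core of compound 1; in this assay compound 3 gives 3690 nM, so that a 5.0-fold higher number from compound 1 to compound 3 (0.70 log units; beyond the scatter). Compound 4 `CCNCC(=O)Nc1cc(OC)ccc1C(=O)c1ccc2c(c1)C=CC(C)(C)O2` is the matching analogue of compound 2, with methyl in place of hydrogen on a saturated chain carbon bound to an amine nitrogen: the same change at the same place, carried onto the other core. The step from compound 2 to compound 4 is expected to be a 5.0-fold higher number from compound 2 to compound 4 (0.69 log units; beyond the scatter), resting on the single measured case, a 5.0-fold higher number from compound 1 to compound 3 (0.70 log units; beyond the scatter), and on compound 2 lying within the scatter of compound 1. For compound 4 the estimate is 5000 nM, with a range from 2000 nM to 12000 nM.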

Compound 4, half-maximal inhibitory concentration: 3990 nM
Compound 4: the middle estimate sits 1.3-fold (0.10 log units) above what was measured; low and high end bracket the measured number.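

In this assay the change from methylamino to ethylamino gives a 4.0-fold higher number from compound 2 to compound 4 (0.60 log units; beyond the scatter), and this step agrees with the earlier one: the same change on two cores in this assay, a 5.0-fold higher number (0.70 log units; beyond the scatter) from compound 1 to compound 3 and a 4.0-fold higher number (0.60 log units; beyond the scatter) from compound 2 to compound 4, 1.3-fold (0.10 log units) apart, within the scatter of two such steps. Within this series, the change therefore carries from the core of compound 1 to the core of compound 2 in the same direction and at much the same size. These two pairs, read in one cell assay, do not show how the change would behave on any other core, and they do not explain why the number rises.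

On these data alone, how a primary amine or a longer chain such as propylamino would read in this place on either core remains open. As far as these compounds go, a cyclic amine such as pyrrolidine is equally open.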